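Swapping Chloro for Bromo on a Shared Core

This account rests on a few compounds, and the source may have more. Where it says the series, first, only, none or still open, it means among the compounds named here.

Compound 1 `COc1cc2c(cc1OC)C(c1ccc(Cl)cc1)=NNC(=O)C2` was tested in a functional assay on the whole organism with Mus musculus as the target (a higher number here means that more compound is needed for the effect, a lower number that less compound is needed), where it gives 75.3 umol/kg, the highest of the two numbers shown. Its nearest neighbour is compound 3 `COc1cc2c(cc1OC)C(c1ccc(N)cc1)=NN(C)C(=S)C2`, which in this assay gives 20.3 umol/kg, a gap beyond the usual scatter. For compound 2 `COc1cc2c(cc1OC)C(c1cccc([N+](=O)[O-])c1)=NNC(=O)C2` the result in this assay is only a limit, > 120 umol/kg; this is the limit of > 120 umol/kg in this assay, at which 1 of the 3 values shown sits. The new compound 4 `COc1cc2c(cc1OC)C(c1ccc(Br)cc1)=NNC(=O)C2` differs from compound 1 in one place: bromo in place of chloro on an aromatic carbon. Within the data shown here, no measured pair differs in just this way, so the step is expected to be small, in either direction, and not beyond the scatter a 1.1-fold lower number from compound 1 to compound 4 (0.03 log units; within the scatter). Compound 4 is therefore expected to give in this assay about 70 umol/kg, between 35 umol/kg and 140 umol/kg.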

Compound 4, dose for half-maximal effect: 82.5 umol/kg
For compound 4 the middle estimate is 1.2-fold (0.07 log units) below the measured one; low and high end bracket the measured number.
By their numbers in this assay, from the lowest: compound 3; then compounds 1 and 4 (each within the scatter of the next). At a limit, above all of these: compound 2.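

Replacing the 4-chlorophenyl group with 4-bromophenyl in this assay gives a 1.1-fold higher number from compound 1 to compound 4 (0.04 log units; within the scatter), so the two halogens cannot be told apart at this position. This is the first pair shown that differs in only one place, which gives the first direct reading of a change on this ring. Nothing shown explains why the two results agree.

As far as these compounds go, whether fluoro or a carboxylic acid in the same place on the shared core would give a similar number remains open. So does whether any group there would produce a step beyond the scatter.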